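Return of an indole to the aryl position

A few compounds are considered here, and "the series" means these few. Any claim that something is new, unique, unknown or untested is made for them only; others in the source may bear on it.

Of the compounds shown here, three on one shared core have been measured in a functional assay on B16-F0 cells (Mus musculus) for inhibition, read by CCK-8 assay, with a stated time of 48 h; a lower number here means a stronger inhibitor, a higher number a weaker inhibitor. Compound 1 `COc1cc(-c2ccnc3cc(-c4c[nH]c5ccccc45)nn23)cc(OC)c1OC` gives 40 nM, compound 2 `COc1cc(-c2ccnc3cc(-c4ccc(C)c(C)c4)nn23)cc(OC)c1OC` gives 391 nM and compound 3 `COc1cc(-c2ccnc3cc(-c4ccc(C(F)(F)F)cc4)nn23)cc(OC)c1OC` gives 1770 nM, the highest number of the three. Compound 4 `COc1cc(-c2ccnc3cc(-c4cn(C)c5ccccc45)nn23)cc(OC)c1OC` is still unmeasured. Its difference from compound 3 is 1-methyl-1H-indol-3-yl in place of 4-(trifluoromethyl)phenyl on an aromatic carbon.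

The closest evidence is the large step of a 44-fold higher number from compound 1 to compound 3 (1.65 log units; beyond the scatter), read here in reverse. The modest steps of a 9.8-fold higher number from compound 1 to compound 2 (0.99 log units; beyond the scatter) and a 4.5-fold higher number from compound 2 to compound 3 (0.66 log units; beyond the scatter) also bear on it, since both phenyl-type groups give higher numbers than 1H-indol-3-yl. Within the data shown here, no measured pair shows what a methyl on the indole does, so the expectation carries real uncertainty. A large drop in the number is expected, a 30-fold lower number from compound 3 to compound 4 (1.47 log units; beyond the scatter). For compound 4 the estimated value is 60 nM, with an expected range of 18 nM to 220 nM.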

Compound 4, half-maximal inhibitory concentration: 185 nM
Compound 4: middle estimate off by 3.1-fold (0.49 log units), on the low side; measured number inside the range.
By their numbers in this assay, from the lowest: compound 1; then compound 4; then compound 2; then compound 3.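

In (this assay) the methyl on the aromatic nitrogen of the indole is the first change shown on that group itself, and it raises the number (a 4.6-fold higher number from compound 1 to compound 4 (0.67 log units; beyond the scatter)), so the unsubstituted 1H-indol-3-yl stays the best group at this position. The methylated indole keeps part of the advantage over the phenyl-type groups, with a modest gain over 4-(trifluoromethyl)phenyl (a 9.6-fold lower number from compound 3 to compound 4 (0.98 log units; beyond the scatter)) and a smaller one, only just beyond the scatter, over 3,4-dimethylphenyl (a 2.1-fold lower number from compound 2 to compound 4 (0.33 log units; beyond the scatter)). Nothing available explains the rise on methylation.

As far as these compounds go, whether an ethyl or a longer chain on that nitrogen raises the number further remains open. So does the effect of a chain ending in an amine or a carboxylic acid there.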